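Swapping a nitro group for methoxy on compound 2

The source may report more compounds than this note shows. Statements on the series, on what has been measured and on what is new or still open speak of the compounds shown alone.

Compound 2, `COc1cc(C2CC(c3ccc([N+](=O)[O-])cc3)=NN2C(C)=O)ccc1OCc1cn(Cc2ccc([N+](=O)[O-])cc2)nn1`, gives 59% in a functional assay on THP-1 cells (Homo sapiens) for inhibition, read by sulforhodamine B assay, tested at 100 uM; on this read-out higher numbers stand for more inhibition of growth at the one concentration tested and lower numbers for less inhibition of growth. Compound 1, `COc1cc(C2CC(c3ccc(OCc4cn(Cc5ccc([N+](=O)[O-])cc5)nn4)cc3)=NN2C(C)=O)ccc1Oc1cn(Cc2ccc([N+](=O)[O-])cc2)nn1`, gives 15% in this assay, and compound 3, `COc1cc(C2CC(c3ccccc3)=NN2C(C)=O)ccc1OCc1cn(Cc2ccc([N+](=O)[O-])cc2)nn1`, gives 10%. Compound 2 therefore stands highest of the three, with its gaps to compound 1 and to compound 3 both beyond the scatter of the measurement. Compound 4, `COc1ccc(C2=NN(C(C)=O)C(c3ccc(OCc4cn(Cc5ccc([N+](=O)[O-])cc5)nn4)c(OC)c3)C2)cc1`, has not yet been measured. It differs from compound 2 by methoxy in place of nitro on an aromatic carbon. Within the data shown here, one measured step bears directly on this change: a number 49 percentage points lower from compound 2 to compound 3 (beyond the scatter), where the same nitro group was removed and hydrogen left in its place. That step was large and downward. Methoxy is not hydrogen, and no measured pair shows methoxy at this place, so the exact size remains open; still, a clear fall is the expectation. Compound 4 is expected to give 20%, in a range from 5% to 45%, meaning an expected step of a number 39 percentage points lower from compound 2 to compound 4 (beyond the scatter).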

Compound 4, percent growth inhibition at one concentration: 14%
Compound 4: middle estimate off by 6 percentage points, on the high side; measured number inside the range.
By their numbers in this assay, from the lowest: compounds 3, 4 and 1 (each within the scatter of the next); then compound 2.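

In this assay, replacing the 4-nitrophenyl group of compound 2 with 4-methoxyphenyl gives a number 45 percentage points lower from compound 2 to compound 4 (beyond the scatter), so the fall seen earlier on removing the nitro group is not confined to a swap for bare hydrogen. Methoxy in place of hydrogen gives a number 4 percentage points higher from compound 3 to compound 4 (within the scatter), which means that methoxy and hydrogen cannot be told apart at this position on this read-out, and of the three groups compared here only the nitro group goes with the high number. Nothing available here explains why the nitro group stands apart from the other two.

Going by these compounds, it remains open whether any other group at this position, such as an amine, a nitrile or a carboxylic acid, could match the nitro group. On these data alone, it also remains open whether a chlorine atom there would fall with methoxy and hydrogen or stay near compound 2.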